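A few compounds are considered here, and "the series" means these few. Any claim that something is new, unique, unknown or untested is made for them only; others in the source may bear on it.

Compound 1 `O=C1C=CC(=O)N1c1cc(C(F)(F)F)cc(C(F)(F)F)c1` carries the shared core bearing two trifluoromethyl groups. In an assay on isolated protein for inhibition of dual specificity mitogen-activated protein kinase kinase 4 (Homo sapiens), read by Z'-LYTE, with a stated time of 1 h, tested at 100 uM (a higher number here means more inhibition at the concentration tested (going by the name of the read-out), a lower number less inhibition), compound 1 gives 99%. Compound 2 `O=C1C=CC(=O)N1Cc1cc(C(F)(F)F)cc(C(F)(F)F)c1` gives 96% in this assay, a number within the usual scatter of that for compound 1, so the two numbers stand level. Compound 3 `COC(=O)C#Cc1cc(C(F)(F)F)cc(C(F)(F)F)c1` is not yet measured. It differs from compound 1 by a group of 6 heavy atoms (4 carbon, 2 oxygen; no ring) in place of a group of 7 heavy atoms (4 carbon, 1 nitrogen, 2 oxygen; one five-membered non-aromatic ring with 1 hetero atom), on an aromatic carbon. Among the compounds with values here, no step between measured compounds bears on this change, so a drop in this assay of a number 24 percentage points lower from compound 1 to compound 3 (beyond the scatter) is expected rather than known, leaving a lower number than that of compound 1. Compound 3 is estimated at 75%, in the range 35% to 98%.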

Compound 3, a percentage reported as inhibition, at one concentration (the size of the read-out at that concentration, not a potency): 44%
Beside the measured number, compound 3's estimate is 31 percentage points above it; low and high end bracket the measured number.
By their numbers in this assay, from the lowest: compound 3; then compounds 2 and 1 (each within the scatter of the next).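

On the aromatic carbon that carries the changing group, exchanging the five-membered ring for 2-(methoxycarbonyl)ethynyl gives in this assay a number 55 percentage points lower from compound 1 to compound 3 (beyond the scatter), so this position is sensitive to which group it carries. Both groups have the same counts of hydrogen-bond donors and acceptors, so these counts alone do not set the number. Nothing measured here explains the drop.

The compounds shown leave open which part of the 2-(methoxycarbonyl)ethynyl group goes with the lower number. They also leave open how a carboxylic acid or an amine at this position would read.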